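Widening the Saturated Ring Beside the Nitro Group

A few compounds are considered here, and "the series" means these few. Any claim that something is new, unique, unknown or untested is made for them only; others in the source may bear on it.

Compound 1 `COc1cc[nH]c1/C=C1\C(=O)Nc2ccc([N+](=O)[O-])cc21` gives 692 nM in a functional assay on RKO cells (Homo sapiens) for antiproliferative activity, read by MTT assay, with a stated time of 5 days; a lower number here means a stronger inhibitor, a higher number a weaker inhibitor. Compound 2 `COc1cc[nH]c1/C=C1\C(=O)Nc2ccc([N+](=O)[O-])c(N3CC[C@@H](N)C3)c21` reaches in this assay a reading of < 10 nM, which is a limit of the assay rather than a number (the limit of < 10 nM in this assay, at which 1 of the 3 values shown sits). Compound 3 `COc1cc[nH]c1/C=C1\C(=O)Nc2ccc([N+](=O)[O-])c(N3CC[C@@H](O)C3)c21` gives 32 nM in this assay, the lowest of the two proper numbers, with compound 1 the nearest. The step of a 22-fold lower number from compound 1 to compound 3 (1.33 log units; beyond the scatter) is large, and the step of an at least 3.2-fold higher number from compound 2 to compound 3 (0.50 log units; beyond the scatter) is at least modest. Compound 4 `COc1cc[nH]c1/C=C1\C(=O)Nc2ccc([N+](=O)[O-])c(N3CCCC(CO)C3)c21` has not yet been measured; it differs from compound 3 in that (3-(hydroxymethyl)piperidin-1-yl in place of 3-hydroxypyrrolidin-1-yl on an aromatic carbon). Among the compounds with values here, no measured step alters the size of the saturated ring or moves the hydroxy onto a carbon outside it, so only two steps bear on this one: the large gain on adding the hydroxypyrrolidine to compound 1, and the at least modest loss on exchanging amino for hydroxy. The counted difference shows the same number of donors and acceptors retained, and the account therefore expects only a small step, within or just beyond the scatter, with direction uncertain. The estimate for compound 4 in this assay is 50 nM, between 15 nM and 200 nM. This estimate means a step of a 1.6-fold higher number from compound 3 to compound 4 (0.19 log units; within the scatter).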

Compound 4, half-maximal inhibitory concentration: 124 nM
Estimate against measurement, compound 4: 2.5-fold (0.39 log units) below; the measured number falls inside the stated range.
By their numbers in this assay, from the lowest: compound 3; then compound 4; then compound 1. At a limit, below all of these: compound 2.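

In this assay, within the data shown here, 3-(hydroxymethyl)piperidin-1-yl still improves on the hydrogen of the core (a 5.6-fold lower number from compound 1 to compound 4 (0.75 log units; beyond the scatter)), so this position, ortho to a nitro group, accepts a six-membered ring carrying a hydroxymethyl group as well as the five-membered rings of the earlier compounds. The exchange is nevertheless not neutral (a 3.9-fold higher number from compound 3 to compound 4 (0.59 log units; beyond the scatter); an at least 12-fold higher number from compound 2 to compound 4 (1.09 log units; beyond the scatter)), even though 3-(hydroxymethyl)piperidin-1-yl and 3-hydroxypyrrolidin-1-yl have the same counted hydrogen-bond donors and acceptors, so those counts alone do not set the reading at this position. The reading of compound 2 in that comparison is a limit of the assay and not a number: the limit of < 10 nM in this assay, at which 1 of the 4 values shown sits.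

The change from compound 3 to compound 4 alters the ring size, the placement of the hydroxy and the defined stereocentre together, and these compounds cannot separate the three; 3-hydroxypiperidin-1-yl or 3-(hydroxymethyl)pyrrolidin-1-yl, each with its stereochemistry defined, would begin to do so. On these data alone, it also remains open whether an amine on the six-membered ring, as in 3-aminopiperidin-1-yl, would give a reading closer to that of compound 2.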